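Losing a Chlorine, Gaining an Amino Link: Compound 4 Expected

The source may hold more compounds than are shown below. What is called first, only, known or untested is meant among the compounds shown, and "the series" means these compounds.

Measured so far in a functional assay on SK-OV-3 cells (Homo sapiens) for cytotoxicity, read by sulforhodamine B assay, with a stated time of 48 h; on this read-out higher numbers stand for weaker inhibition and lower numbers for stronger inhibition:
compound 1 `O=c1cc(-c2ccccc2)oc2cc(OCCCCNc3nc4ccc(Cl)cc4s3)cc(O)c12` gives 39.3 ug/mL
compound 2 `O=c1cc(-c2ccccc2)oc2cc(OCCCCNc3nc4ccc(C(F)(F)F)cc4s3)cc(O)c12` gives 37.2 ug/mL
compound 3 `O=C(O)c1ccc2nc(NCCCCOc3cc(O)c4c(=O)cc(-c5ccccc5)oc4c3)sc2c1` gives 43.3 ug/mL

Among the measured compounds shown here, of these three numbers, the one for compound 1 is the second highest, though all three sit within the scatter of one another. Its nearest neighbour is compound 2: a 1.1-fold lower number from compound 1 to compound 2 (0.02 log units; within the scatter). Its furthest is compound 3: a 1.1-fold higher number from compound 1 to compound 3 (0.04 log units; within the scatter). Compound 2 and compound 3 are likewise close: a 1.2-fold higher number from compound 2 to compound 3 (0.07 log units; within the scatter). In every measured step only the group on an aromatic carbon of the benzothiazole was exchanged, and the read-out did not move.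

Compound 4 `O=c1cc(-c2ccccc2)oc2cc(OCCCCNNc3nc4ccccc4s3)cc(O)c12` takes a different step from compound 1: (1,3-benzothiazol-2-yl)amino in place of 6-chloro-1,3-benzothiazol-2-yl on an amine nitrogen. The chlorine is gone, and a further amino group enters on the amine nitrogen attached to the saturated chain carbon. For the measured compounds named here, no measured step alters this link, so the three steps bear on it only indirectly: they show that changes at the far end of the benzothiazole left this assay unmoved. With no closer guide, the expected step of a 1.0-fold higher number from compound 1 to compound 4 (0.01 log units; within the scatter) is none beyond the scatter. Compound 4 is therefore estimated at 40 ug/mL, with an expected range from 20 ug/mL to 80 ug/mL.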

Compound 4, half-maximal inhibitory concentration: 51.7 ug/mL
Compound 4: middle estimate off by 1.3-fold (0.11 log units), on the low side, within the range that was stated.
By their numbers in this assay, from the lowest: compounds 2, 1, 3 and 4 (each within the scatter of the next).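

The earlier steps shown here only exchanged a group on the benzothiazole, whereas compound 4 changes the link itself: a further amino group enters on the amine nitrogen attached to the saturated chain carbon, and the ring carries no substituent. In this assay, this gives a 1.3-fold higher number from compound 1 to compound 4 (0.12 log units; within the scatter) and, against the carboxy compound, a 1.2-fold higher number from compound 3 to compound 4 (0.08 log units; within the scatter), so the read-out stays within the scatter even when the link is altered and the chloro or carboxy group is absent. Nothing available explains this result or says how these compounds act on the cells.

Compound 4 carries both changes at once, so the compounds shown cannot separate the effect of the added amino group from that of losing the ring substituent. Going by these compounds, it also remains open whether an amide in the link, or a longer chain, would move the number beyond the scatter.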